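Fluoro for Tert-Butyl on a Quinoline Urea

The source may hold more compounds than are shown below. What is called first, only, known or untested is meant among the compounds shown, and "the series" means these compounds.

Measured compounds:
- compound 1, `Cc1cc(NC(=O)Nc2ccccc2C(C)(C)C)c2ccccc2n1`, gives > 25000 nM in an ADME assay on Raji cells (Homo sapiens) for cytotoxicity, with a stated time of 72 h; a lower number here means that less compound is needed, a higher number that more compound is needed for the effect
- compound 2, `Cc1cc(NC(=O)Nc2ccc(C(N)=O)cc2)c2ccccc2n1`, gives > 25000 nM in this assay

Both of these numbers are limits of the assay, not measured values. Compound 1 stands at the limit of > 25000 nM in this assay, at which 2 of the 2 values shown sit. Compound 2 stands at the same limit, so nothing separates the two compounds on the numbers shown, and no step between measured compounds can be drawn from them.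

Compound 3, `Cc1cc(NC(=O)Nc2ccccc2F)c2ccccc2n1`, has not yet been measured in this assay. Compared with compound 1 it shows (fluoro in place of tert-butyl on an aromatic carbon). Since compound 1 itself sits at the limit, the change from compound 1 to compound 3 is expected to be a step that the limit leaves unreadable from compound 1 to compound 3, that is, none beyond the scatter. Compound 3 is therefore estimated at 30000 nM, within a range from 8000 nM to 100000 nM, most likely again reported only as a limit.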

Compound 3, half-maximal effective concentration: > 25000 nM
Compound 3 gave a limit, no number; the forecaster's own chance of this, stated with the estimate: 80%; the middle value lies beyond the limit too.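

In this assay compound 3 gives > 25000 nM as a limit, not a number. For the compounds shown here, compound 1 also sits at a limit, so no step between compound 1 and compound 3 can be read: the limit of > 25000 nM in this assay, at which 3 of the 3 values shown sit. As far as these compounds go, whether any compound on this shared core reaches a measurable value in this assay stays open.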